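Moving the phenol across the benzylamine ring

The source may hold more compounds than are shown below. What is called first, only, known or untested is meant among the compounds shown, and "the series" means these compounds.

Compound 1 `COc1ccc(CN[C@@H]2CO[C@H](C(c3ccccc3)c3ccccc3)C[C@H]2O)cc1O` is the weaker of the two measured compounds: in an assay on Cerebral cortex for inhibition of Norepinephrine transporter (Rattus norvegicus) (a higher number here means a weaker inhibitor, a lower number a stronger inhibitor), compound 1 gives 30.2 nM, while the difluorinated analogue compound 2 `Oc1ccc(CN[C@@H]2CO[C@H](C(c3ccc(F)cc3)c3ccc(F)cc3)C[C@H]2O)cc1F` gives 7.37 nM. Compound 3 `COc1cc(CN[C@@H]2CO[C@H](C(c3ccccc3)c3ccccc3)C[C@H]2O)ccc1O` differs from compound 1 only in how the same atoms are joined: 4-hydroxy-3-methoxyphenyl in place of 3-hydroxy-4-methoxyphenyl on a saturated chain carbon bound to an amine nitrogen. Among the compounds with values here, no measured pair shows this swap, so no direction can be read from the data. A step of about a 1.3-fold higher number from compound 1 to compound 3 (0.12 log units; within the scatter) is expected, roughly within the usual scatter and slightly toward weaker binding. Compound 3 is therefore estimated at 40 nM, with a range from 10 nM to 160 nM.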

Compound 3, inhibition constant: 33.7 nM
Estimate against measurement, compound 3: 1.2-fold (0.07 log units) above, and the stated range covers the measured number.
By their numbers in this assay, from the lowest: compound 2; then compounds 1 and 3 (each within the scatter of the next).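

In this assay, putting 4-hydroxy-3-methoxyphenyl in place of 3-hydroxy-4-methoxyphenyl gives a 1.1-fold higher number from compound 1 to compound 3 (0.05 log units; within the scatter). Within the data shown here, on this saturated chain carbon bound to an amine nitrogen, exchanging the hydroxy and methoxy groups therefore leaves the number within the scatter, which the earlier compounds could not show. No supporting data bear on why this exchange leaves the number within the scatter.

As far as these compounds go, it remains open whether an ethoxy group in place of the methoxy, or an amine in place of the hydroxy, would hold the number as well. From the compounds shown here alone, the same exchange on the core of compound 2 also remains open.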